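The source may hold more compounds than are shown below. What is called first, only, known or untested is meant among the compounds shown, and "the series" means these compounds.

Measured in an ADME assay on the whole organism (plasma, strain CD-1) for pharmacokinetics, with Mus musculus as the target, at a dose of 30 mg/kg by the oral route; on this read-out lower numbers stand for lower exposure and higher numbers for higher exposure at the dose given:
- compound 1 `CCCS(=O)(=O)Nc1ccc(Cl)c(C(=O)Nc2cnc3[nH]nc(OC)c3c2)c1F`: 1080000 ng.h/mL
- compound 2 `CCCS(=O)(=O)Nc1ccc(F)c(C(=O)Nc2cnc3[nH]ncc3c2)c1F`: 40000 ng.h/mL
- compound 3 `CCCS(=O)(=O)Nc1ccc(F)c(C(=O)Nc2cnc3[nH]nc(C)c3c2)c1F`: 18300 ng.h/mL

Compound 3 stands lowest of the three numbers. Its nearest neighbour is compound 2; the step of a 2.2-fold lower number from compound 2 to compound 3 (0.34 log units; beyond the scatter) is modest but beyond the scatter. Compound 1, which differs from compound 3 in two places (a methoxy in place of the methyl and a chlorine in place of one fluorine), gives by far the highest number of the set, and its two changes cannot be separated on these data.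

Compound 4 `CCCS(=O)(=O)Nc1ccc(F)c(C(=O)Nc2cnc3[nH]nc(N(C)C)c3c2)c1F` has not yet been measured. It differs from compound 3 as follows: dimethylamino in place of methyl on an aromatic carbon. Going by the values given here, none of the measured steps exchanges a methyl for a dimethylamino or introduces an acceptor at this carbon, so the only single-place step available, a 2.2-fold lower number from compound 2 to compound 3 (0.34 log units; beyond the scatter), bears on it indirectly, and the high number of compound 1 is confounded. A small step is therefore expected, a 1.4-fold higher number from compound 3 to compound 4 (0.14 log units; within the scatter), with wide uncertainty. For compound 4 the expected value in this assay is 25000 ng.h/mL, within a range from 7000 ng.h/mL to 90000 ng.h/mL.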

Compound 4, area under the concentration-time curve in the Mus musculus assay: 1090 ng.h/mL
Compound 4: middle estimate off by 23-fold (1.36 log units), on the high side; measured number outside the range, below it.
By their numbers in the Mus musculus assay, from the lowest: compound 4; then compound 3; then compound 2; then compound 1.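

In the Mus musculus assay this aromatic carbon proves far less tolerant than the earlier pair suggested: compound 4 gives 1090 ng.h/mL, dimethylamino in place of methyl gives a 17-fold lower number from compound 3 to compound 4 (1.23 log units; beyond the scatter), and dimethylamino in place of hydrogen gives a 37-fold lower number from compound 2 to compound 4 (1.56 log units; beyond the scatter), both large beside the modest step, a 2.2-fold lower number from compound 2 to compound 3 (0.34 log units; beyond the scatter). In a physicochemical assay for solubility, read by HPLC, in phosphate buffer, with a stated time of 24 h, at pH 7.4 (on this read-out higher numbers stand for higher solubility and lower numbers for lower solubility), compound 3 gives 740 ug/mL and compound 4 gives 450 ug/mL; the same exchange gives a 1.6-fold lower number from compound 3 to compound 4 (0.22 log units; within the scatter), so solubility does not separate the two compounds, while exposure does. Nothing at hand accounts for the loss of exposure.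

The compounds shown leave open whether the methoxy or the chlorine of compound 1 carries its high number. They also leave open whether a plain amino group or a morpholine on this carbon would fall as far as dimethylamino.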